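The compounds below may be only part of what the source reports. "The series", "measured", "known", "first", "only" and "open" are said of these compounds alone.

Measured so far in a physicochemical assay for solubility, at pH 7.4 (a lower number here means a less soluble compound, a higher number a more soluble compound), are three compounds:
Compound 1 `CCc1ccc(NC(=O)Nc2cc(C)nc3ccccc23)cc1` gives 3300 nM
Compound 2 `Cc1cc(NC(=O)Nc2ccccc2N)c2ccccc2n1` gives 51800 nM
Compound 3 `Cc1cc(NC(=O)Nc2ccccc2C(C)(C)C)c2ccccc2n1` gives 100 nM

Compound 2 holds the highest number of the three, and compound 1 and compound 3 both lie lower. Compound 4 `Cc1cc(NC(=O)Nc2cccc(F)c2)c2ccccc2n1` has not yet been measured. It differs from compound 2 by 3-fluorophenyl in place of 2-aminophenyl on an amide-type nitrogen, counted as 3-fluorophenyl in place of 2-aminophenyl on an amide-type nitrogen in full.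

For the measured compounds named here, only one measured step removes the amino group: tert-butyl in place of amino on an aromatic carbon, which gave a 520-fold lower number from compound 2 to compound 3 (2.71 log units; beyond the scatter) and is large. Going by the values given here, no measured step introduces fluorine, so this step guides the direction only, not the size. Compound 1, which also has no amino group, stands at 3300 nM and so sits far closer to compound 2 than compound 3 does. A clear step to a lower number is therefore expected in this assay but a smaller one than that to compound 3.

The expected change is a 10-fold lower number from compound 2 to compound 4 (1.02 log units; beyond the scatter) on this reading. For compound 4 the estimate is 5000 nM with an expected range of 1500 nM to 16000 nM for the measurement.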

Compound 4, solubility: 100 nM
Compound 4: middle estimate off by 50-fold (1.70 log units), on the high side, and the stated range ends above it.
By their numbers in this assay, from the lowest: compounds 3 and 4 (each within the scatter of the next); then compound 1; then compound 2.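

In this assay the change from 2-aminophenyl to 3-fluorophenyl on the amide-type nitrogen gives a 520-fold lower number from compound 2 to compound 4 (2.71 log units; beyond the scatter) and so shows that a second, quite different replacement at this place also ends far from compound 2. Compound 3 gives 100 nM and compound 4 gives 100 nM as two values within the scatter of each other, while compound 1, which also carries no amino group, gives 3300 nM and shows that losing that group does not always lead to the same number. Nothing measured here accounts for these differences.

The compounds shown leave open whether the high number of compound 2 is tied to the amino group alone. A hydroxyl group, a dimethylamino group or a carboxylic acid on the same phenyl ring would begin to answer that.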